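The source may report more compounds than this note shows. Statements on the series, on what has been measured and on what is new or still open speak of the compounds shown alone.

Measured so far in a functional assay on A549 cells (Homo sapiens) for antiproliferative activity, read by MTT assay, with a stated time of 48 h; a higher number here means a weaker inhibitor, a lower number a stronger inhibitor:

compound 1 `C=C(c1ccc(OC)cc1NC(=O)CNC)c1ccc(OC)c2c1C=CC(C)(C)O2`: 320 nM
compound 2 `C=C(c1ccc2c(c1)C=CC(C)(C)O2)c1ccc(OC)cc1NC(=O)CNC`: 200 nM
compound 3 `C=C(c1ccc(OC)cc1NC(=O)CNCC)c1ccc(OC)c2c1C=CC(C)(C)O2`: 1870 nM

Compound 1 and compound 2 differ in their cores; the difference between the two cores is not broken down here, and their two values lie within the scatter of each other. Within the data shown here, compound 1 and compound 3 differ by one change, (methyl in place of hydrogen on a saturated chain carbon bound to an amine nitrogen), and the step of a 5.8-fold higher number from compound 1 to compound 3 (0.77 log units; beyond the scatter) is the only single-place step measured in this assay.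

Compound 4 `C=C(c1ccc2c(c1)C=CC(C)(C)O2)c1ccc(OC)cc1NC(=O)CNCC` is not yet measured. It stands to compound 2 as compound 3 stands to compound 1, through the same change, (methyl in place of hydrogen on a saturated chain carbon bound to an amine nitrogen). Among the measured compounds shown here, on the core of compound 2 the step is expected to be of like size, a 5.0-fold higher number from compound 2 to compound 4 (0.70 log units; beyond the scatter), because the only precedent is a 5.8-fold higher number from compound 1 to compound 3 (0.77 log units; beyond the scatter) on the core of compound 1. Compound 4 is therefore expected to give about 1000 nM, roughly between 400 nM and 2500 nM.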

Compound 4, half-maximal inhibitory concentration: 1180 nM
Compound 4: middle estimate off by 1.2-fold (0.07 log units), on the low side; low and high end bracket the measured number.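

In this assay the change from methylamino to ethylamino gives a 5.9-fold higher number from compound 2 to compound 4 (0.77 log units; beyond the scatter) on the core of compound 2, and the size of the step carries over between the two cores: the same change on two cores in this assay, a 5.8-fold higher number (0.77 log units; beyond the scatter) from compound 1 to compound 3 and a 5.9-fold higher number (0.77 log units; beyond the scatter) from compound 2 to compound 4, 1.0-fold (0.00 log units) apart, within the scatter of two such steps.

On these two cores the change can therefore be treated as a step of constant size. Among these compounds, this rests on only two matched pairs in a single cell assay, so it shows nothing about other cores or other assays, and it does not explain why the step has this size.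

Still open, on these data alone, is how a primary amine, a dimethylamino group or a longer chain such as propylamino would compare. As far as these compounds go, whether either core would tolerate these groups equally is also open.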